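Three aryl variants on one core, and a bromophenyl analogue

The source may hold more compounds than are shown below. What is called first, only, known or untested is meant among the compounds shown, and "the series" means these compounds.

Measured compounds:
compound 1, `CC(c1ccc(-c2ccccc2)c(F)c1)c1nnc2n1N=C(c1ccc(OC(F)(F)F)cc1)CS2`, in a functional assay on HCT-116 cells (Homo sapiens) for inhibition, read by sulforhodamine B assay, with a stated time of 72 h (on this read-out lower numbers stand for stronger inhibition and higher numbers for weaker inhibition), compound 1 gives 5400 nM
compound 2, `CC(c1ccc(-c2ccccc2)c(F)c1)c1nnc2n1N=C(c1ccc(Cl)cc1Cl)CS2`, in which compound 2 gives 6900 nM
compound 3, `CC(c1ccc(-c2ccccc2)c(F)c1)c1nnc2n1N=C(c1ccc(C(F)(F)F)cc1)CS2`, in which compound 3 gives 6100 nM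

The three share a core and differ only in the aryl group on the carbon with a double bond to nitrogen. On the numbers shown, compound 3 sits between the other two, and both of its steps are small: a 1.1-fold higher number from compound 1 to compound 3 (0.05 log units; within the scatter), and a 1.1-fold lower number from compound 2 to compound 3 (0.05 log units; within the scatter). The remaining pair is no different: a 1.3-fold higher number from compound 1 to compound 2 (0.11 log units; within the scatter). Within this set, then, changing the aryl group has produced nothing beyond the scatter.

Compound 4, `CC(c1ccc(-c2ccccc2)c(F)c1)c1nnc2n1N=C(c1ccc(Br)cc1)CS2`, is not yet measured. It differs from compound 3 by bromo in place of trifluoromethyl on an aromatic carbon. Within the data shown here, the steps that bear on this are the swap of trifluoromethoxy for trifluoromethyl at the same aromatic carbon, a 1.1-fold higher number from compound 1 to compound 3 (0.05 log units; within the scatter), and the swap of a whole aryl group, a 1.1-fold lower number from compound 2 to compound 3 (0.05 log units; within the scatter); both were within the scatter. Among the measured compounds shown here, no measured step alters this position by more than the scatter, so the expectation for this assay is a step of no real size in either direction, a 1.0-fold lower number from compound 3 to compound 4 (0.01 log units; within the scatter). Compound 4 is therefore estimated at 6000 nM, with a likely range from 3000 nM to 12000 nM.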

Compound 4, half-maximal inhibitory concentration: 7100 nM
Beside the measured number, compound 4's estimate is 1.2-fold (0.07 log units) below it, within the range that was stated.
By their numbers in this assay, from the lowest: compounds 1, 3, 2 and 4 (each within the scatter of the next).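

In this assay, bromo at this aromatic carbon, para to a large group, takes the place of trifluoromethyl with a 1.2-fold higher number from compound 3 to compound 4 (0.07 log units; within the scatter), so going from 4 heavy atoms to 1 at this spot yields no step beyond the scatter. The comparisons with the other two aryl groups read the same way, with a 1.0-fold higher number from compound 2 to compound 4 (0.01 log units; within the scatter) and a 1.3-fold higher number from compound 1 to compound 4 (0.12 log units; within the scatter), which extends the flat picture on the shared core to a fourth aryl group, one carrying a single bromo, and leaves all four compounds within the scatter of one another. Nothing measured here speaks to the reason for this flatness.

From the compounds shown here alone, the four aryl groups bear only halogens or fluorinated groups, and whether an amine, a carboxylic acid or a longer chain at this aromatic carbon would also stay within the scatter remains open. Equally open is whether a change elsewhere on the shared core would move the number at all, as every step shown lies in this one aryl group.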